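A few compounds are considered here, and "the series" means these few. Any claim that something is new, unique, unknown or untested is made for them only; others in the source may bear on it.

Compound 1 `CN(C)C(=O)c1cc2cnc(Nc3ccc(S(=O)(=O)NCCCN=C=S)cc3)nc2n1C1CCCC1` was tested in a functional assay on NCI-H1299 cells (Homo sapiens) for inhibition, read by CCK-8 assay, with a stated time of 72 h, tested at 10 uM (a lower number here means a weaker effect, a higher number a stronger effect of the compound at the concentration tested), and gave 72.8%. Among the three compounds measured so far, compound 1 stands second highest. Its nearest neighbour is compound 2 `CN(C)C(=O)c1cc2cnc(Nc3ccc(C(=O)NCCCCCCN=C=S)cc3F)nc2n1C1CCCC1`, which in this assay gives 77.6%, a gap that lies within the usual scatter of the measurement. The furthest is compound 3 `CN(C)C(=O)c1cc2cnc(Nc3ccc(C(=O)NCCCCCCCN=C=S)cc3F)nc2n1C1CCCC1`, which in this assay gives 35.8%, a gap that lies beyond the scatter.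

Compound 4 `CN(C)C(=O)c1cc2cnc(Nc3ccc(N=C=S)cc3)nc2n1C1CCCC1` is the next compound to be measured. Compared with compound 1, the change is a group of 3 heavy atoms (1 carbon, 1 nitrogen, 1 sulfur; no ring) in place of a group of 10 heavy atoms (4 carbon, 2 nitrogen, 2 oxygen, 2 sulfur; no ring), on an aromatic carbon. For the measured compounds named here, the only step already measured, a number 41.8 percentage points lower from compound 2 to compound 3 (beyond the scatter), shows that even a single extra chain carbon between the amide-type nitrogen and the terminal group can move the inhibition a long way downward. That step does not cover the change at hand, which removes the whole tether rather than lengthening it, so it gives direction only loosely. The expectation is therefore uncertain, with a moderate loss more likely than a gain: compound 4 is estimated at 55%, with a range from 25% to 85%, which would mean a step of a number 17.8 percentage points lower from compound 1 to compound 4 (beyond the scatter).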

Compound 4, a percentage reported as inhibition, at one concentration (the size of the read-out at that concentration, not a potency): 83.7%
The estimate for compound 4 lay 28.7 percentage points below the measured number, and the stated range covers the measured number.
By their numbers in this assay, from the lowest: compound 3; then compounds 1, 2 and 4 (each within the scatter of the next, the first and the last beyond it).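

On the aromatic carbon para to a large group, the group of 10 heavy atoms in compound 1 can be given up entirely: in this assay, putting the group of 3 heavy atoms in its place gives a number 10.9 percentage points higher from compound 1 to compound 4 (beyond the scatter). This pair shows that, in this read-out, the long sulfonamide-bearing tether and its hydrogen-bond donor are not required for inhibition, and that the smaller group attached straight to the aromatic carbon does more than merely hold on to the effect. No measurement shown here accounts for this gain in inhibition, so the reason for it remains unknown.

The compounds shown leave open whether the group of 3 heavy atoms is itself what matters, a question that an amine or a carboxylic acid on the same aromatic carbon of the core of compound 4 could begin to answer. They also leave open how inhibition changes along a series of tethers on this core, from a very short alkyl chain to a longer chain, and each read-out here is the size of the effect at one concentration rather than a potency.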